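A few compounds are considered here, and "the series" means these few. Any claim that something is new, unique, unknown or untested is made for them only; others in the source may bear on it.

Within the data shown here, in a functional assay on A549 cells (Homo sapiens) for antiproliferative activity, read by sulforhodamine B assay, with a stated time of 48 h (on this read-out lower numbers stand for stronger inhibition and higher numbers for weaker inhibition), compound 1 `COc1ccc(C[C@@H](O)/C=C/C=C/C(=O)N2CCN(C)CC2)cc1OC` gives 22200 nM and compound 2 `COc1ccc(C[C@@H](O)/C=C/C=C/C(=O)N2CCN(c3ccccc3)CC2)cc1OC` gives 14200 nM, so compound 1 stands within the usual scatter of the only other measured compound. Compound 3 `COc1ccc(C[C@@H](O)/C=C/C=C/C(=O)NCc2ccccc2)cc1OC` is not yet measured. It has benzylamino in place of 4-methylpiperazin-1-yl on a carbonyl carbon. Among the measured compounds shown here, only one measured step bears on this change, and only loosely: a 1.6-fold lower number from compound 1 to compound 2 (0.19 log units; within the scatter), with phenyl in place of methyl on an amine nitrogen in a ring. No step beyond the scatter is therefore expected, and the estimated step is a 1.4-fold lower number from compound 1 to compound 3 (0.14 log units; within the scatter). Compound 3 is expected at about 16000 nM, with an estimated range of 6000 nM to 40000 nM.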

Compound 3, half-maximal inhibitory concentration: 17100 nM
The estimate for compound 3 lay 1.1-fold (0.03 log units) below the measured number; measured number inside the range.
By their numbers in this assay, from the lowest: compounds 2, 3 and 1 (each within the scatter of the next).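

The earlier pair changed only the group on a ring nitrogen, whereas here the whole 4-methylpiperazin-1-yl gives way to benzylamino, so a hydrogen-bond donor enters and an aromatic ring of carbon only replaces the non-aromatic ring. Even so, this assay shows a 1.3-fold lower number from compound 1 to compound 3 (0.11 log units; within the scatter) at this place on the carbonyl carbon. No measurement shown here accounts for this result. Still open, from the compounds shown here alone, is whether morpholin-4-yl on the same carbonyl carbon, or a carboxylic acid in place of the amide, would move the number beyond the scatter.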